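Oxime variants on a thioether-linked diaryl series

A few compounds are considered here, and "the series" means these few. Any claim that something is new, unique, unknown or untested is made for them only; others in the source may bear on it.

Measured so far:
- compound 1, `CN(C)/C(=N\O)c1ccc(Sc2cc(F)cc(C3CCOCC3)c2)cc1`: 280 nM
- compound 2, `C/C(=N/O)c1ccc(COc2cc(F)cc(C3CCOCC3)c2)cc1`: 40 nM

In a functional assay (blood) for inhibition, with Homo sapiens as the target (a lower number here means a stronger inhibitor, a higher number a weaker inhibitor), compound 1 stands at the higher of the two numbers; compound 2 sits a good way lower, and that gap lies beyond the scatter. Among the measured compounds shown here, compound 2 differs from compound 1 in more than one place, so no single step between measured compounds is available.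

Compound 3, `C/C(=N\OC(=O)N(C)C)c1ccc(Sc2cc(F)cc(C3CCOCC3)c2)cc1`, is not yet measured. It differs from compound 1 in one place: a group of 9 heavy atoms (5 carbon, 2 nitrogen, 2 oxygen; no ring) in place of a group of 6 heavy atoms (3 carbon, 2 nitrogen, 1 oxygen; no ring), on an aromatic carbon. For the measured compounds named here, no measured pair shows this change, so the direction has to be judged from the structures alone. A modest step downward is expected, a 1.9-fold lower number from compound 1 to compound 3 (0.27 log units; within the scatter), though a result within the scatter of compound 1 would not surprise. Compound 3 is therefore estimated at 150 nM, with a range from 40 nM to 600 nM.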

Compound 3, half-maximal inhibitory concentration: 2610 nM
Estimate against measurement, compound 3: 17-fold (1.24 log units) below, outside the stated range (above it).
By their numbers in this assay, from the lowest: compound 2; then compound 1; then compound 3.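

In this assay this position does not tolerate every change: the group of 9 heavy atoms in place of the group of 6 heavy atoms, on an aromatic carbon para to a large group, gives a 9.3-fold higher number from compound 1 to compound 3 (0.97 log units; beyond the scatter) and so moves the series towards weaker inhibition. The entering group counts 0 hydrogen-bond donors against 1 in the leaving group, and 3 hydrogen-bond acceptors against 2, but this single pair cannot separate those counts from the larger size of the group. Nothing available accounts for the rise.

The pair also changes the oxime oxygen and the carbon attached to the oxime together, so the contribution of each stays unresolved. From the compounds shown here alone, whether an acetyl group or a methyl ether on that oxygen would keep the number close to that of compound 1 remains open.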